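A few compounds are considered here, and "the series" means these few. Any claim that something is new, unique, unknown or untested is made for them only; others in the source may bear on it.

Measured compounds in a functional assay on MGC-803 cells (Homo sapiens) for inhibition, read by MTT assay, with a stated time of 72 h; a higher number here means a weaker inhibitor, a lower number a stronger inhibitor:
Compound 1, `O=C(OCc1ccccc1)N1CCN(C(=S)SCc2cn(Cc3ccc(Cl)cc3)nn2)CC1`, gives 31300 nM.
Compound 2, `CC(C)(C)OC(=O)N1CCN(C(=S)SCc2cn(Cc3ccc(Cl)cc3)nn2)CC1`, gives 9790 nM.
Compound 3, `CC(C)(C)OC(=O)N1CCN(C(=S)SCc2cn(Cc3ccccc3Cl)nn2)CC1`, gives 490 nM.

Compound 2 and compound 3 share all atoms and differ only in how they are joined: 2-chlorophenyl in place of 4-chlorophenyl on a saturated chain carbon bound to an aromatic nitrogen. That rearrangement carries a 20-fold lower number from compound 2 to compound 3 (1.30 log units; beyond the scatter), and compound 3 stands lowest of the three measured numbers. Compound 1 differs from compound 2 by benzyl in place of tert-butyl on an oxygen next to a carbonyl group, which gives a 3.2-fold higher number from compound 2 to compound 1 (0.50 log units; beyond the scatter).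

Compound 4, `O=C(OCc1ccccc1)N1CCN(C(=S)SCc2cn(Cc3ccccc3Cl)nn2)CC1`, has not yet been measured in this assay. It differs from compound 3 by benzyl in place of tert-butyl on an oxygen next to a carbonyl group. Within the data shown here, the place is worded identically in both pairs, so this is the same change as that from compound 2 to compound 1; it appears in these two pairs and nowhere else among the compounds here, so the only guide is that single measured step.

The expectation for compound 4 is a step of about a 3.1-fold higher number from compound 3 to compound 4 (0.49 log units; beyond the scatter), resting on compound 2 to compound 1 showing a 3.2-fold higher number from compound 2 to compound 1 (0.50 log units; beyond the scatter), applied to the core of compound 3 with its value of 490 nM. Whether the shift carries over unchanged onto the core of compound 3 is not tested by anything measured, so the range is kept wide. Compound 4 is estimated at 1500 nM, between 500 nM and 5000 nM.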

Compound 4, half-maximal inhibitory concentration: 15500 nM
The estimate for compound 4 lay 10-fold (1.01 log units) below the measured number; the measured number lies above the stated range.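

In this assay, benzyl in place of tert-butyl gives a 32-fold higher number from compound 3 to compound 4 (1.50 log units; beyond the scatter), and this change does not keep its size from one core to the other: the same change on two cores in this assay, a 3.2-fold higher number (0.50 log units; beyond the scatter) from compound 2 to compound 1 and a 32-fold higher number (1.50 log units; beyond the scatter) from compound 3 to compound 4, 9.9-fold (1.00 log units) apart, beyond the scatter of two such steps. The 2-chlorophenyl in place of 4-chlorophenyl change gives a 2.0-fold lower number from compound 1 to compound 4 (0.31 log units; beyond the scatter), and its size likewise depends on the core that carries it: the same change on two cores in this assay, a 20-fold lower number (1.30 log units; beyond the scatter) from compound 2 to compound 3 and a 2.0-fold lower number (0.31 log units; beyond the scatter) from compound 1 to compound 4, 9.9-fold (1.00 log units) apart, beyond the scatter of two such steps. Each change keeps its direction on both cores, so the two changes are not additive across these four compounds, but this does not show why they interact, and one pair per core gives no rule for the size of either change on a further core.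

From the compounds shown here alone, it remains open whether an ethyl group or a longer chain in place of tert-butyl or benzyl would show the same dependence on the chlorophenyl group. A plain phenyl group in place of either chlorophenyl group would also help show whether the chlorine position or the oxygen substituent sets the size of these steps.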